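Aryl swap at the exocyclic arm of compound 3

This account rests on a few compounds, and the source may have more. Where it says the series, first, only, none or still open, it means among the compounds named here.

Measured in a functional assay on HeLa cells (Homo sapiens) for cytotoxicity, read by CCK-8 assay, with a stated time of 72 h; a lower number here means a stronger inhibitor, a higher number a weaker inhibitor:
- compound 1 `C=CCn1c(=O)/c(=C\c2cccc(C)c2)[nH]c(=O)/c1=C\c1ccccc1OC`: 19300 nM
- compound 2 `COc1ccccc1/C=c1/[nH]c(=O)/c(=C\c2ccccc2OC)[nH]c1=O`: "not active" (no number reported) (no number reported)
- compound 3 `C=CCn1c(=O)/c(=C\c2cccc(F)c2)[nH]c(=O)/c1=C\c1ccccc1OC`: 9100 nM

Compound 3 holds the lowest of the two numbers in this assay; compound 1 sits a step above it, a 2.1-fold lower number from compound 1 to compound 3 (0.33 log units; beyond the scatter) when read in the other direction, and compound 2 gives no number at all. Compound 4 `C=CCn1c(=O)/c(=C\c2ccc(C)cc2)[nH]c(=O)/c1=C\c1ccccc1OC` is not yet measured. It differs from compound 3 in one place: 4-methylphenyl in place of 3-fluorophenyl on a double-bonded chain carbon bound to an aromatic carbon. Among the compounds with values here, the only measured step that speaks to this is the one from compound 1 to compound 3, a 2.1-fold lower number from compound 1 to compound 3 (0.33 log units; beyond the scatter), where fluoro in place of methyl on an aromatic carbon brought the number down. Compound 4 reverses that exchange, methyl returning for fluoro, and also shifts the substituent to a different aromatic carbon, for which no comparison exists. The number for compound 4 is therefore expected to move back up towards compound 1, a 2.2-fold higher number from compound 3 to compound 4 (0.34 log units; beyond the scatter), with wide uncertainty. The estimate for compound 4 is 20000 nM, within 8000 nM to 50000 nM.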

Compound 4, half-maximal inhibitory concentration: "not active" (no number reported)
Nothing numeric was reported for compound 4; there is nothing to compare the estimate with.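

In this assay, within the data shown here, compound 4 is reported as not active, without a number, so no step from compound 3 can be read. No measurement shown offers an explanation for this result. The compounds shown leave open the size of the difference between 4-methylphenyl and 3-fluorophenyl on the shared core.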